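This account rests on a few compounds, and the source may have more. Where it says the series, first, only, none or still open, it means among the compounds named here.

Going by the values given here, compound 2 `CC(C)C(c1ccc(-c2ccc3cccc(F)c3c2)[nH]c1=O)N1CCCCC1=O` is one of three compounds measured in an ADME assay on microsomes from liver (Homo sapiens) for metabolic stability; a lower number here means that the compound disappears faster, a higher number that the compound lasts longer. Compound 2 gives 0.183 h, the lowest of the two numbers shown. Its nearest neighbour, compound 1 `CC(C)[C@H](C[C@H]1CCNC1=O)c1ccc(-c2ccc3cccc(F)c3c2)[nH]c1=O`, gives 0.257 h, a gap that lies within the scatter. Compound 3 `CCn1ncc2c(F)cc(-c3ccc(C(CC)(CC)c4ncn(C)n4)c(=O)[nH]3)cc21` returns only a limit of the assay, > 3 h, and so gives no number (the limit of > 3 h in this assay, at which 1 of the 3 values shown sits). The unmeasured compound 4 `CC(C)C(CC(N)=O)c1ccc(-c2ccc3cccc(F)c3c2)[nH]c1=O` differs from compound 2 in one place: carbamoylmethyl in place of 2-oxopiperidin-1-yl on a saturated chain carbon bound to an aromatic carbon and a saturated chain carbon. Among the compounds with values here, no step between measured compounds in this assay follows this change, so the expectation rests on compound 2 alone; the step of a 2.2-fold higher number from compound 2 to compound 4 (0.34 log units; beyond the scatter) is expected to be modest and upward, though it may stay within the scatter. Compound 4 is estimated at 0.4 h, with a likely range from 0.15 h to 1 h.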

Compound 4, half-life: < 0.0667 h
Compound 4 was reported as a limit (the forecaster's own chance of this, stated with the estimate: 5%); at least 5.9-fold (0.77 log units) between middle value and limit.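

In this assay compound 4 is reported only as a limit of the assay: the limit of < 0.0667 h in this assay, at which 1 of the 4 values shown sits. On this saturated chain carbon, carbamoylmethyl in place of 2-oxopiperidin-1-yl gives an at least 2.7-fold lower number from compound 2 to compound 4 (0.43 log units; beyond the scatter) and so shows that the half-life responds to the group at this position. This change shortens the half-life, even though the group that leaves is the larger one and the one with a ring.

From the compounds shown here alone, how far compound 4 lies past its limit stays open, so the full size of the step cannot be told. Also open, going by these compounds, is how an amine, a carboxylic acid or a longer chain would behave at this carbon.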